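Adding a methoxy group on the other ring of compound 3

The source may hold more compounds than are shown below. What is called first, only, known or untested is meant among the compounds shown, and "the series" means these compounds.

In a functional assay on the whole organism for inhibition, with Rattus norvegicus as the target, at a dose of 1 mg/kg by the oral route (a lower number here means a weaker effect, a higher number a stronger effect of the compound at the dose given), the three measured compounds give:
compound 1 `CNc1ccc(-c2cc(OC)cc(C(=O)Nc3nn[nH]n3)n2)cc1`: 35%
compound 2 `CNc1ccc(-c2cccc(C(=O)Nc3nn[nH]n3)n2)cc1`: 71%
compound 3 `Cc1cc(C(=O)Nc2nn[nH]n2)nc(-c2ccccc2)c1`: 23%

Compound 2 and compound 1 share a core and differ by one change, (methoxy in place of hydrogen on an aromatic carbon). This change gave a number 36 percentage points lower from compound 2 to compound 1 (beyond the scatter). Compound 3 has a different core; how its core differs from that of compound 2 is not broken down here, and its value in this assay is the lowest of the three.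

Compound 4 `COc1cccc(-c2cc(C)cc(C(=O)Nc3nn[nH]n3)n2)c1` has not yet been measured. It differs from compound 3 by methoxy in place of hydrogen on an aromatic carbon. Among the compounds with values here, this is the same kind of change as the one from compound 2 to compound 1, but not the same: there the methoxy entered on a six-membered aromatic ring with 1 nitrogen, opposite the ring nitrogen, whereas here it enters on a six-membered aromatic ring of carbon only, meta to a large group.

Within the data shown here, because the only measured example of this kind of change, a number 36 percentage points lower from compound 2 to compound 1 (beyond the scatter), lowered the read-out, and because compound 3 already starts low at 23%, compound 4 is expected to show a small drop, a number 9 percentage points lower from compound 3 to compound 4 (within the scatter). Compound 4 is thus estimated at 14%, with a range from 0% to 38%.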

Compound 4, a percentage reported as inhibition, in the whole organism at one dose (the size of the read-out at that dose, not a potency): 25%
Compound 4: the middle estimate sits 11 percentage points below what was measured; measured number inside the range.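

In this assay methoxy in place of hydrogen on an aromatic carbon gave a number 2 percentage points higher from compound 3 to compound 4 (within the scatter) and so made no readable difference on this core. The same kind of change therefore cannot be assumed to have the same effect when it is carried from one core to another in this series, as the two available steps show: the same change on two cores in this assay, a number 36 percentage points lower (beyond the scatter) from compound 2 to compound 1 and a number 2 percentage points higher (within the scatter) from compound 3 to compound 4, 38 percentage points apart, beyond the scatter of two such steps. This comparison does not show why the two results part, since the steps differ both in their core and in the ring that takes the methoxy, and two steps cannot separate those differences.

The compounds shown leave open whether a methoxy on the ring of carbon only would also leave the read-out unchanged on the core of compound 2, which would help to tell the effect of the core from that of the ring. They also leave open whether another group in the same place, such as ethoxy or a fluorine atom, would change the read-out on either core.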